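The compounds below may be only part of what the source reports. "The series", "measured", "known", "first", "only" and "open" are said of these compounds alone.

Measured in a functional assay on MCF7 cells (Homo sapiens) for antiproliferative activity, read by sulforhodamine B assay, with a stated time of 48 h; a higher number here means a weaker inhibitor, a lower number a stronger inhibitor
Compound 1 `CCCN1CCN(c2ccc(S(=O)(=O)Oc3ccccc3CC)cc2)C1=O` gives 2300 nM
Compound 2 `CCCN1CCN(c2ccc(S(=O)(=O)Oc3cc(Cl)c(Cl)cc3Cl)cc2)C1=O` gives 13000 nM

Compound 2 at 13000 nM is the higher of the two numbers and so the weaker inhibitor. The change to compound 3 `CCCN1CCN(c2ccc(S(=O)(=O)Oc3cccc(F)c3)cc2)C1=O` is 3-fluorophenyl in place of 2,4,5-trichlorophenyl on an oxygen with 3-fluorophenyl in place of 2,4,5-trichlorophenyl on an oxygen. Within the data shown here, one measured step bears on it, the modest 5.7-fold higher number from compound 1 to compound 2 (0.75 log units; beyond the scatter) which brought in 2,4,5-trichlorophenyl in place of 2-ethylphenyl. Among the measured compounds shown here, with that group leaving, a step of similar size toward a lower number is expected in this assay although no measured compound carries 3-fluorophenyl. The expected step is a 3.7-fold lower number from compound 2 to compound 3 (0.57 log units; beyond the scatter). Compound 3 is estimated at 3500 nM with an expected range from 1000 nM to 10000 nM.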

Compound 3, half-maximal inhibitory concentration: 24000 nM
Estimate against measurement, compound 3: 6.9-fold (0.84 log units) below; measured number outside the range, above it.
By their numbers in this assay, from the lowest: compound 1; then compounds 2 and 3 (each within the scatter of the next).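

In this assay, the group on the oxygen bearing the sulfonyl sulfur can be 2,4,5-trichlorophenyl or 3-fluorophenyl without the two being told apart (a 1.8-fold higher number from compound 2 to compound 3 (0.27 log units; within the scatter)). Compound 1 now stands apart from both, since 2-ethylphenyl also gives a large gap to 3-fluorophenyl (a 10-fold higher number from compound 1 to compound 3 (1.02 log units; beyond the scatter)). Nothing available explains why 2-ethylphenyl differs from these groups.

Only compound 1 carries an alkyl group on this ring, so the result cannot be generalised to alkyl groups. The compounds shown leave open how a propyl chain, a methoxy group, an amine or a carboxylic acid would read here.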